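Nitrophenyl Ester Position Shift in the Dihydro Series

The compounds below may be only part of what the source reports. "The series", "measured", "known", "first", "only" and "open" are said of these compounds alone.

Three esters of the same phenolic cores have been run in a functional assay on SK-LU-1 cells (Homo sapiens) for antiproliferative activity, read by sulforhodamine B assay, with a stated time of 48 h, tested at 50 uM (on this read-out higher numbers stand for more inhibition at the one concentration tested (going by the name of the read-out) and lower numbers for less inhibition), at the single concentration. Compound 1 `CC1=CC[C@H](C(C)C)c2cc(C)c(OC(=O)c3ccc([N+](=O)[O-])cc3)cc21` gives 47.5% in this assay. Compound 2 `Cc1cc2c(C(C)C)ccc(C)c2cc1OC(=O)c1ccc([N+](=O)[O-])cc1`, the aromatised counterpart carrying the same 4-nitrophenyl ester, gives 100%, and the methoxy analogue of compound 2, compound 3 `COc1ccc(C(=O)Oc2cc3c(C)ccc(C(C)C)c3cc2C)cc1`, gives 32.8%. Compound 1 therefore stands second of the three: its number sits between that of compound 3 and that of compound 2, both gaps beyond the scatter.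

For the measured compounds named here, the one measured step, a number 67.2 percentage points lower from compound 2 to compound 3 (beyond the scatter), concerns the exchange of the nitro group for methoxy on the aromatised core and is large. It does not touch the question posed by compound 4 `CC1=CC[C@H](C(C)C)c2cc(C)c(OC(=O)c3cccc([N+](=O)[O-])c3)cc21`, which keeps the nitro group and the dihydro core of compound 1 and differs only in 3-nitrophenyl in place of 4-nitrophenyl on a carbonyl carbon. Going by the values given here, no measured pair shows a move of a nitro group around the ring, so nothing in the data bears directly on this step, and the default expectation is a step within the scatter, in no fixed direction.

Compound 4 is accordingly expected near the parent, with a step of a number 2.5 percentage points lower from compound 1 to compound 4 (within the scatter), giving an estimate of 45% in this assay, between 22% and 70%.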

Compound 4, a percentage reported as inhibition, at one concentration (the size of the read-out at that concentration, not a potency): 60.4%
Beside the measured number, compound 4's estimate is 15.4 percentage points below it; the range from low to high includes it.
By their numbers in this assay, from the lowest: compound 3; then compound 1; then compound 4; then compound 2.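

In this assay, the nitro group's place on the ester ring matters on the core of compound 1: 3-nitrophenyl in place of 4-nitrophenyl on a carbonyl carbon gives a number 12.9 percentage points higher from compound 1 to compound 4 (beyond the scatter). The earlier compounds shown here showed only an exchange of one group for another on a different core, whereas here the atoms stay the same and only the way they are joined changes, so arrangement alone is enough to give a step beyond the scatter, though a modest one beside the large a number 67.2 percentage points lower from compound 2 to compound 3 (beyond the scatter). No measurement at hand speaks to the origin of this step.

The compounds shown leave open whether the same move would raise the number on the core of compound 2, where the 4-nitrophenyl ester of compound 2 already gives 100%. They also leave open whether an amine or a carboxylic acid in place of the nitro group on this ring would hold the level of compound 4 on the shared core.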